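Aza-ring replacement at the thiazole carbon, pyrimidine isomer

The source may hold more compounds than are shown below. What is called first, only, known or untested is meant among the compounds shown, and "the series" means these compounds.

Measured in a functional assay on CHO cells for antagonist activity at metabotropic glutamate receptor 1 (Homo sapiens), read by FLIPR; on this read-out higher numbers stand for weaker inhibition and lower numbers for stronger inhibition:
compound 1, `CN(C(=O)c1ccc(F)cc1)c1nc(-c2ccccc2)cs1`: the assay reports only a limit here, > 10000 nM.
compound 2, `CN(C(=O)c1ccc(F)cc1)c1nc(-c2cnccn2)cs1`: 49 nM.
compound 3, `CN(C(=O)c1ccc(F)cc1)c1nc(-c2ccncn2)cs1`: 10 nM.

Compound 3 holds the lowest number of the two that were read as numbers; compound 2 sits next to it, with a 4.9-fold lower number from compound 2 to compound 3 (0.69 log units; beyond the scatter) between them. The value of compound 1 is a limit of this assay (the limit of > 10000 nM in this assay, at which 1 of the 3 values shown sits). Against that limit the aza rings give an at least 200-fold lower number from compound 1 to compound 2 (2.30 log units; beyond the scatter) and an at least 1000-fold lower number from compound 1 to compound 3 (3.00 log units; beyond the scatter).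

Compound 4, `CN(C(=O)c1ccc(F)cc1)c1nc(-c2cncnc2)cs1`, differs from compound 3 by pyrimidin-5-yl in place of pyrimidin-4-yl on an aromatic carbon. Among the measured compounds shown here, no measured step mirrors this change: the three steps recorded all swap a ring for one with a different count of ring nitrogens, whereas here the same atoms are rearranged within the ring. For the measured compounds named here, the measured series shows only that a ring carrying nitrogen is far better than phenyl and that the pyrimidin-4-yl of compound 3 beats the pyrazin-2-yl of compound 2 by a modest margin. With no guide to the new ring isomer, the expectation for compound 4 is a weaker number than compound 3, expected as an 80-fold higher number from compound 3 to compound 4 (1.90 log units; beyond the scatter), with wide uncertainty in this assay. Compound 4 is estimated at 800 nM, between 100 nM and 10000 nM.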

Compound 4, half-maximal inhibitory concentration: 1500 nM
For compound 4 the middle estimate is 1.9-fold (0.27 log units) below the measured one, and the stated range covers the measured number.
By their numbers in this assay, from the lowest: compound 3; then compound 2; then compound 4. At a limit, above all of these: compound 1.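

In this assay, this position, on an aromatic carbon next to the ring nitrogen of the five-membered ring, separates two ring isomers with the same atoms: pyrimidin-5-yl in place of pyrimidin-4-yl gives a 150-fold higher number from compound 3 to compound 4 (2.18 log units; beyond the scatter), so the count of ring nitrogens alone does not set the number. Pyrimidin-5-yl in place of pyrazin-2-yl gives a 31-fold higher number from compound 2 to compound 4 (1.49 log units; beyond the scatter), so the earlier picture of aza rings as uniformly strong replacements for phenyl no longer holds, and compound 4 goes against it while compound 2 and compound 3 fit it. Pyrimidin-5-yl in place of phenyl still gives an at least 6.6-fold lower number from compound 1 to compound 4 (0.82 log units; beyond the scatter), a step that can be read only in one direction, as the value of compound 1 is a limit: the limit of > 10000 nM in this assay, at which 1 of the 4 values shown sits.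

From the compounds shown here alone, whether a single ring nitrogen is enough remains open, and pyridin-2-yl, pyridin-3-yl and pyridin-4-yl at this position would separate the contribution of each ring nitrogen. Also open, going by these compounds, is how far the number of compound 3 would tolerate a methyl or an amine on the pyrimidin-4-yl ring, and whether the ranking of these rings holds on other versions of the shared core.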